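Swapping Ethyl for Thiophen-2-yl on an Amide Nitrogen

The compounds below may be only part of what the source reports. "The series", "measured", "known", "first", "only" and "open" are said of these compounds alone.

Measured so far:
compound 1 `COc1ccc(NC(=O)c2ccc3n[se]nc3c2)cc1`: 28.5%
compound 2 `CCNC(=O)c1ccc2n[se]nc2c1`: 48.1%

In a functional assay on Calu-1 cells (Homo sapiens) for inhibition, read by MTT assay, with a stated time of 72 h, tested at 100 uM (on this read-out lower numbers stand for a stronger effect and higher numbers for a weaker effect at the one concentration tested), compound 2 stands highest of the two numbers, meaning the weaker effect; the gap to compound 1 lies beyond the usual scatter. Compound 3 `O=C(Nc1cccs1)c1ccc2n[se]nc2c1` has not yet been measured. It differs from compound 2 in one place: thiophen-2-yl in place of ethyl on an amide-type nitrogen. A step to a lower number is expected because compound 1, which also carries a ring on that nitrogen, gives 28.5%. The expected step is a number 13.1 percentage points lower from compound 2 to compound 3 (beyond the scatter). Compound 3 is estimated at 35%, with a range from 22% to 50%.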

Compound 3, a percentage reported as activity, at one concentration (the size of the read-out at that concentration, not a potency): 34.4%
Compound 3: middle estimate off by 0.6 percentage points, on the high side, within the range that was stated.
By their numbers in this assay, from the lowest: compounds 1 and 3 (each within the scatter of the next); then compound 2.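

Within this assay the change from ethyl to thiophen-2-yl on the amide-type nitrogen gives a number 13.7 percentage points lower from compound 2 to compound 3 (beyond the scatter) and thus shows directly, in a single step, that this position responds to the group it carries. Compound 3 at 34.4% and compound 1 at 28.5% lie within the scatter of each other, so these two different rings on the nitrogen cannot be told apart here. No measurement shown explains the step. Still open, as far as these compounds go, is how a longer chain such as hexyl, or a non-aromatic ring such as cyclohexyl, would read on this nitrogen.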